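Replacing the sulfanyl ester chain of compound 3

The compounds below may be only part of what the source reports. "The series", "measured", "known", "first", "only" and "open" are said of these compounds alone.

Compound 1 `CCCCC1([C@H](O)/C=C/C2CCC(=O)[C@@H]2CCCCCC(=O)O)CCC1` gives 0.032 mg/kg
Compound 2 `CCCCC1([C@@H](O)/C=C/C2CCC(=O)[C@@H]2CCCCCCC(=O)OCC)CCC1` gives 0.032 mg/kg
Compound 3 `CCCCC1([C@H](O)/C=C/C2CCC(=O)[C@@H]2CCCCSCC(=O)OCC)CCC1` gives 0.03 mg/kg

In a functional assay on the whole organism (strain Hartley) for inhibition, with Cavia porcellus as the target, with stated times of 15 min and 2 min (a lower number here means that less compound is needed, a higher number that more compound is needed for the effect), compound 3 gives 0.03 mg/kg, which lies within the scatter of compound 1 and compound 2. Compound 4 `CCCCC1([C@H](O)/C=C/C2CCC(=O)[C@@H]2CCCCCCC(=O)OCC)CCC1` has not yet been measured. Its difference from compound 3 is 2-(ethoxycarbonyl)ethyl in place of ((ethoxycarbonyl)methyl)sulfanyl on a saturated chain carbon, four bonds along the chain from a saturated ring carbon, with 2-(ethoxycarbonyl)ethyl in place of ((ethoxycarbonyl)methyl)sulfanyl on a saturated chain carbon, four bonds along the chain from a saturated ring carbon. Going by the values given here, the one measured step at this place is a 1.1-fold lower number from compound 1 to compound 3 (0.03 log units; within the scatter), and it stayed within the scatter. No step beyond the scatter is therefore expected in this assay. The expected step is no change at the digits printed from compound 3 to compound 4 (within the scatter). For compound 4 the estimated value is 0.03 mg/kg, with an expected range from 0.01 mg/kg to 0.09 mg/kg.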

Compound 4, dose for half-maximal effect: 0.0151 mg/kg
The estimate for compound 4 lay 2.0-fold (0.30 log units) above the measured number, and the stated range covers the measured number.
By their numbers in this assay, from the lowest: compounds 4, 3, 1 and 2 (each within the scatter of the next, the first and the last beyond it).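

Putting 2-(ethoxycarbonyl)ethyl in place of ((ethoxycarbonyl)methyl)sulfanyl gives a 2.0-fold lower number from compound 3 to compound 4 (0.30 log units; within the scatter), so in this assay this position tolerates the all-carbon chain as well as the sulfur-containing one. Going by these compounds alone, two modest steps beyond the scatter appear for the first time: a 2.1-fold lower number from compound 1 to compound 4 (0.33 log units; beyond the scatter), with (ethoxycarbonyl)methyl in place of carboxy, and a 2.1-fold lower number from compound 2 to compound 4 (0.33 log units; beyond the scatter), at a stereocentre on a saturated chain carbon. The stereo step needs one caution: the fact that one of compounds 2 and 4 is drawn with a defined configuration and the other without, at the place where they differ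

On these data alone, whether an amide in place of the ester, or an oxygen atom in place of the chain sulfur, would hold this level in this assay stays open.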